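Swapping pyridin-4-yl for 3-fluorophenyl in compound 1

This account rests on a few compounds, and the source may have more. Where it says the series, first, only, none or still open, it means among the compounds named here.

Of the compounds shown here, two sharing one core have been measured so far in a functional assay on MCF-10A cells (Homo sapiens) for antiproliferative activity, with a stated time of 48 h; a higher number here means that more compound is needed for the effect, a lower number that less compound is needed. Compound 1 (`COc1ccc2nc(C)cc(NCc3ccncc3)c2c1`) gives 41600 nM, the higher number of the pair, so more of it is needed for the effect. Compound 2 (`COc1ccc2nc(C)cc(NCc3ccc(C(C)(C)C)cc3)c2c1`) gives 7000 nM.

Compound 3 (`COc1ccc2nc(C)cc(NCc3cccc(F)c3)c2c1`) has not been measured yet. It keeps the core of compound 1 and changes one group, with 3-fluorophenyl in place of pyridin-4-yl on a saturated chain carbon bound to a nitrogen on an aromatic ring. Among the compounds with values here, the only guide is compound 2, which also carries no pyridin-4-yl in that place and gives 7000 nM, so a lower number looks likelier than a higher one. Its group is not 3-fluorophenyl, though, so only part of that gap is expected to carry over. The expected change in this assay is therefore a moderate drop, estimated as a 2.8-fold lower number from compound 1 to compound 3 (0.44 log units; beyond the scatter). The estimated value for compound 3 is 15000 nM, with an expected range of 6000 nM to 40000 nM.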

Compound 3, half-maximal effective concentration: 14700 nM
Estimate against measurement, compound 3: 1.0-fold (0.01 log units) above; measured number inside the range.
By their numbers in this assay, from the lowest: compound 2; then compound 3; then compound 1.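

With the core of compound 1 held fixed, the group on this saturated chain carbon bound to a nitrogen on an aromatic ring can be changed with a clear effect in this assay: 3-fluorophenyl in place of pyridin-4-yl gives a 2.8-fold lower number from compound 1 to compound 3 (0.45 log units; beyond the scatter). The lower number of compound 2 is therefore not the only case in which a ring of carbon only at this place goes with less compound being needed, although compound 3, at 14700 nM, does not reach compound 2, at 7000 nM. No measurement at hand explains why the number falls with this change.

This single step removes the ring nitrogen and adds a fluorine together, so the two contributions cannot be told apart, and an unsubstituted phenyl at this place would be needed to separate them. From the compounds shown here alone, what a ring bearing a carboxylic acid or an amine would do in this assay also remains open, as does whether the fluorine's place on the ring matters.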